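The compounds below may be only part of what the source reports. "The series", "measured", "known", "first", "only" and "open" are said of these compounds alone.

In a functional assay on HGC-27 cells (Homo sapiens) for antiproliferative activity, read by MTT assay, with stated times of 72 h and 4 h (a higher number here means a weaker inhibitor, a lower number a stronger inhibitor), compound 1 `COc1ncc(-c2cc3c(N4C[C@@H](C)O[C@@H](C)C4)ncnc3s2)cc1NS(=O)(=O)c1ccc(F)cc1F` gives 560 nM. Compound 2 `COc1ncc(-c2cc3c(N4CC(C)OC(C)C4)ncnc3s2)cc1NS(=O)(=O)c1ccc(F)cc1F`, which has the same atoms and bonds but no drawn configuration at its two ring stereocentres, gives 860 nM, and compound 3 `COc1ncc(-c2cc3c(N4CCCCC4)ncnc3s2)cc1NS(=O)(=O)c1ccc(F)cc1F` gives 1200 nM. Two steps place this last value among the others: a 1.4-fold higher number from compound 2 to compound 3 (0.14 log units; within the scatter), and a 2.1-fold higher number from compound 1 to compound 3 (0.33 log units; beyond the scatter).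

Compound 4 `COc1ncc(-c2cc3c(N4CCCC4)ncnc3s2)cc1NS(=O)(=O)c1ccc(F)cc1F` alters only the ring on the aromatic carbon of the shared core, with pyrrolidin-1-yl in place of piperidin-1-yl on an aromatic carbon. Within the data shown here, the only steps that bear on this change are the two above, which also swap the group at this place. Both were small, one within the scatter and one only modestly beyond it. Neither tests a five-membered ring, so they give no firm direction, and no step beyond the scatter is expected in this assay. The expected step is a 1.2-fold lower number from compound 3 to compound 4 (0.08 log units; within the scatter). For compound 4 the estimated value is 1000 nM, with an expected range from 400 nM to 2500 nM.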

Compound 4, half-maximal inhibitory concentration: 2300 nM
The estimate for compound 4 lay 2.3-fold (0.36 log units) below the measured number; measured number inside the range.
By their numbers in this assay, from the lowest: compounds 1, 2, 3 and 4 (each within the scatter of the next, the first and the last beyond it).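

In this assay, the change from piperidin-1-yl to pyrrolidin-1-yl on its own stays inside the usual scatter (a 1.9-fold higher number from compound 3 to compound 4 (0.28 log units; within the scatter)), so this position gives no clear read on the loss of one ring carbon. Among these compounds, the new information comes from the comparison with 2,6-dimethylmorpholin-4-yl: pyrrolidin-1-yl is the first group here to lie beyond the scatter from both the defined and the undefined form of that ring, though only modestly (a 2.7-fold higher number from compound 2 to compound 4 (0.43 log units; beyond the scatter); a 4.1-fold higher number from compound 1 to compound 4 (0.61 log units; beyond the scatter)). The available evidence offers no explanation for these steps.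

Morpholin-4-yl without its two methyl groups would help separate the part played by the ring oxygen from that of the methyl groups. An open-chain amine such as dimethylamino would show whether this position needs a ring at all.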